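Rat Clearance After a Change on an Aromatic Carbon

This account rests on a few compounds, and the source may have more. Where it says the series, first, only, none or still open, it means among the compounds named here.

In an ADME assay on the whole organism (strain Sprague-Dawley) for pharmacokinetics, with Rattus norvegicus as the target, using cassette dosing (on this read-out lower numbers stand for slow clearance and higher numbers for fast clearance), compound 1 `O=c1[nH]c2ccc(-c3cc(C[C@]4(O)CC[C@@H](Cc5ccccc5)CC4)no3)cc2o1` gives 12.1 mL/min/kg. For compound 2 `O=c1[nH]c2ccc(-c3cc(C[C@]4(O)CC[C@@H](Cc5ccc(Cl)cc5)CC4)no3)cc2o1` the entry reads "not determined" (no result reported), so compound 2 has no single number to stand on. Compound 3 `O=c1ccc(-c2cc(C[C@]3(O)CC[C@@H](Cc4ccc(Cl)cc4)CC3)no2)c[nH]1` is still unmeasured. The structural change is a group of 7 heavy atoms (5 carbon, 1 nitrogen, 1 oxygen; one six-membered aromatic ring with 1 hetero atom) in place of a group of 10 heavy atoms (7 carbon, 1 nitrogen, 2 oxygen; one five-membered aromatic ring with 2 hetero atoms, one six-membered aromatic ring of carbon only), on an aromatic carbon, a smaller group entering on an aromatic carbon. Going by the values given here, no measured step bears on this change, so no shift beyond the usual scatter is expected in this assay, and no direction is favoured. Among the compounds with values here, the only anchor is compound 1 at 12.1 mL/min/kg. For compound 3 the clearance is estimated at 12 mL/min/kg, with an expected range of 5 mL/min/kg to 28 mL/min/kg.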

Compound 3, clearance: 16.8 mL/min/kg
Estimate against measurement, compound 3: 1.4-fold (0.15 log units) below, and the stated range covers the measured number.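

Going by these compounds alone, compound 2 has no number in this assay, so no step to compound 3 can be read. The compounds shown leave open how this change of group bears on clearance, and nothing shown speaks to a cause.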